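The compounds below may be only part of what the source reports. "The series", "measured", "known", "first", "only" and "open" are said of these compounds alone.

Three compounds built on one shared core differ only in the group attached to a single aromatic carbon. Compound 1 `CS(=O)(=O)c1cc(C(=O)N=C(N)N)ccc1-n1cccn1` carries a 1H-pyrazol-1-yl there, and in a functional assay for inhibition of sodium/hydrogen exchanger (Oryctolagus cuniculus) (on this read-out lower numbers stand for stronger inhibition and higher numbers for weaker inhibition), compound 1 gives 160 nM. Compound 2 `CS(=O)(=O)c1cc(C(=O)N=C(N)N)ccc1C#N` carries a cyano instead, and in this assay compound 2 gives 140 nM. Compound 3 `CS(=O)(=O)c1cc(C(=O)N=C(N)N)ccc1C(F)(F)F` carries a trifluoromethyl, and in this assay compound 3 gives 140 nM, level with compound 2 at the digits shown and within the scatter of compound 1. The steps of a 1.1-fold lower number from compound 1 to compound 2 (0.06 log units; within the scatter), a 1.1-fold lower number from compound 1 to compound 3 (0.06 log units; within the scatter) and no change at the digits printed from compound 2 to compound 3 (within the scatter) all stay within the scatter, so three rather different groups at this carbon have left the number essentially unmoved. Compound 4 `Cc1ccc(C(=O)N=C(N)N)cc1S(C)(=O)=O` changes the same position once more: methyl in place of trifluoromethyl on an aromatic carbon. Because no change at the digits printed from compound 2 to compound 3 (within the scatter) and the other exchanges at this carbon stayed within the scatter, the expected step of a 1.1-fold higher number from compound 3 to compound 4 (0.03 log units; within the scatter) is likewise none beyond the scatter. Compound 4 is therefore estimated at 150 nM, with a range from 70 nM to 350 nM.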

Compound 4, half-maximal inhibitory concentration: 210 nM
The estimate for compound 4 lay 1.4-fold (0.15 log units) below the measured number; the measured number falls inside the stated range.
By their numbers in this assay, from the lowest: compounds 2, 3, 1 and 4 (each within the scatter of the next).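

In this assay methyl joins the groups tried at this carbon, and the steps of a 1.5-fold higher number from compound 3 to compound 4 (0.18 log units; within the scatter) and a 1.5-fold higher number from compound 2 to compound 4 (0.18 log units; within the scatter) and a 1.3-fold higher number from compound 1 to compound 4 (0.12 log units; within the scatter) all stay within the scatter. Cutting the group from the 4 heavy atoms of trifluoromethyl to the 1 heavy atom of methyl therefore leaves the number within the scatter, and none of the four compounds goes against this tolerance for different groups at this carbon. No measurement shown explains why this carbon accepts such different groups.

The compounds shown leave open whether the number would also hold with an amine, a carboxylic acid or a longer chain at this carbon. On these data alone, all four also keep the same methylsulfonyl group ortho to the changing group, so whether this tolerance survives a change to that group remains unknown.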